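This account rests on a few compounds, and the source may have more. Where it says the series, first, only, none or still open, it means among the compounds named here.

Of the compounds shown here, two have been measured so far. Compound 1, `C(#Cc1nc(-c2ccccc2)nc2c1ncn2Cc1ccccc1)c1ccccc1`, in a functional assay on K562 cells (Homo sapiens) for inhibition, read by thymidine incorporation, with a stated time of 48 h, tested at 10 ug/mL (on this read-out higher numbers stand for more inhibition at the one concentration tested (going by the name of the read-out) and lower numbers for less inhibition), gives 100%. Compound 2, `COC(=O)/C(C)=C/C#Cc1[nH]cnc2ncnc1-2`, gives in this assay a reading of 100%. Compound 2 thus stands level with compound 1 at the digits shown, and the two readings lie within the scatter of each other, so no order between them can be read off. Both sit at the top of what a single-concentration read-out of this kind can show.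

Compound 3, `C/C(=C\C#Cc1[nH]cnc2ncnc1-2)CO`, has not yet been measured. It differs from compound 2 in one place: hydroxymethyl in place of methoxycarbonyl on a double-bonded chain carbon bound to a double-bonded chain carbon and a saturated chain carbon. The rest of compound 2 is kept unchanged. Among the measured compounds shown here, no measured pair shows what such a change does, so the size of the step can only be estimated. Because compound 2 already gives 100%, there is no room upward, and the step is expected to be either none beyond the scatter or a modest fall. The expected step from compound 2 to compound 3 in this assay is a number 15 percentage points lower from compound 2 to compound 3 (beyond the scatter). Compound 3 is expected to give 85%, with a range from 50% to 100%.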

Compound 3, a percentage reported as inhibition, at one concentration (the size of the read-out at that concentration, not a potency): 17%
Compound 3: the middle estimate sits 68 percentage points above what was measured, and the stated range ends above it.
By their numbers in this assay, from the lowest: compound 3; then compounds 1 and 2 (each within the scatter of the next).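

In this assay, hydroxymethyl in place of methoxycarbonyl on a double-bonded chain carbon bound to a double-bonded chain carbon and a saturated chain carbon gives a number 83 percentage points lower from compound 2 to compound 3 (beyond the scatter). The two earlier compounds both sat at the top of this read-out and so gave no sign of what any one group contributes, whereas this single change shows that the reading depends strongly on the group at this position. Nothing measured here explains the fall.

On these data alone, what remains open is which part of the change matters, the loss of the methoxycarbonyl group or the arrival of the hydroxymethyl group, and a carboxylic acid, a primary amide or an aldehyde on the same double-bonded chain carbon would help to tell these apart. A reading at one concentration also leaves open how compound 1 and compound 2 compare in potency, and whether the gap between compound 2 and compound 3 would look the same at other concentrations.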